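Pyrazole in Place of Tetrazole on the Shared Core

A few compounds are considered here, and "the series" means these few. Any claim that something is new, unique, unknown or untested is made for them only; others in the source may bear on it.

Compound 1 `Cc1cc(C)c(NC(=O)N(Cc2cccc(-c3nnn(C)n3)c2)C2CCCCCC2)c(C)c1` carries a 2-methyl-2H-tetrazol-5-yl on one of its aromatic rings. In a functional assay on a cell-free system (plasma) with sterol O-acyltransferase, Soat (Rattus norvegicus) as the target (on this read-out lower numbers stand for an effect already at smaller amounts and higher numbers for an effect only at larger amounts of compound), compound 1 gives < 1 mg/kg, which is a limit of the assay rather than a number (the limit of < 1 mg/kg in this assay, at which 1 of the 2 values shown sits). Compound 2 `COc1ccccc1CN(Cc1cccc(-c2cc[nH]n2)c1)C(=O)Nc1c(SC)cc(C)nc1SC` differs from compound 1 in several places at once. In this assay compound 2 gives > 0.1 mg/kg, again only a limit (the limit of > 0.1 mg/kg in this assay, at which 1 of the 2 values shown sits). Both readings are limits. Among the compounds with values here, neither compound can be ranked against the other, and no measured step joins them.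

Compound 3 `Cc1cc(C)c(NC(=O)N(Cc2cccc(-c3cnn(C)c3)c2)C2CCCCCC2)c(C)c1` differs from compound 1 in a single place: 1-methyl-1H-pyrazol-4-yl in place of 2-methyl-2H-tetrazol-5-yl on an aromatic carbon. Within the data shown here, no measured pair in this set informs that exchange, so the expectation rests on compound 1 alone. Compound 1 offers only its limit < 1 mg/kg as a starting point. The step of a number no lower from compound 1 to compound 3 (the limit leaves the size open) is expected to be small, no larger than the usual scatter, in either direction. The estimated value for compound 3 in this assay is 1 mg/kg, with a range from 0.3 mg/kg to 3 mg/kg.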

Compound 3, dose for half-maximal effect: < 1 mg/kg
Compound 3 ended at the assay's limit; the forecaster's own chance of this, stated with the estimate: 50%; the middle value sits exactly at the limit.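

The exchange of 2-methyl-2H-tetrazol-5-yl for 1-methyl-1H-pyrazol-4-yl yields no readable step between compound 1 and compound 3 in this assay, because both readings are only limits: the limit of < 1 mg/kg in this assay, at which 2 of the 3 values shown sit. The compounds shown leave open how far below that limit compound 1 and compound 3 each lie, and so whether the exchange changes the dose at all.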